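This account rests on a few compounds, and the source may have more. Where it says the series, first, only, none or still open, it means among the compounds named here.

Working notes on the series. In a functional assay on HeLa cells (Homo sapiens) for inhibition, read by MTT assay, with a stated time of 48 h (on this read-out lower numbers stand for stronger inhibition and higher numbers for weaker inhibition), compound 1 (`CCc1ccc(-c2nc3ccccn3c2Sc2ccccc2)cc1`) gives 52100 nM and compound 2 (`Clc1ccc2nc(-c3ccccc3)c(Sc3ccccc3)n2c1`) gives 29300 nM. Among the measured compounds shown here, these two values lie within the scatter of each other, so compound 1 stands level with the only other measured number. Compound 3 (`c1ccc(Sc2c(-c3ccsc3)nc3ccccn23)cc1`) awaits testing in this assay. It carries thiophen-3-yl in place of 4-ethylphenyl on an aromatic carbon of the core of compound 1: thiophen-3-yl in place of 4-ethylphenyl on an aromatic carbon. For the measured compounds named here, no measured pair differs in one place only, so the data hold no direct measure of this change. Going by the values given here, compound 2 at 29300 nM is the sole reference beside compound 1, and it gives no ground for expecting a large move. The expected 1.3-fold lower number from compound 1 to compound 3 (0.11 log units; within the scatter) stays within the scatter, with no firm direction. Compound 3 is estimated at 40000 nM, with an expected range of 15000 nM to 100000 nM.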

Compound 3, half-maximal inhibitory concentration: 76000 nM
Compound 3: the middle estimate sits 1.9-fold (0.28 log units) below what was measured, within the range that was stated.
By their numbers in this assay, from the lowest: compounds 2, 1 and 3 (each within the scatter of the next, the first and the last beyond it).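

In this assay, the change at this position now has a direct measure: thiophen-3-yl in place of 4-ethylphenyl gives a 1.5-fold higher number from compound 1 to compound 3 (0.16 log units; within the scatter). On this aromatic carbon, a five-membered aromatic ring with a sulfur atom and a six-membered carbon ring bearing an ethyl group therefore stand level, so this exchange of aromatic groups opens no measurable gap. Nothing in the available data bears on the reason for this result.

Open, as far as these compounds go, is whether a group of another kind on this carbon, such as an amine, a carboxylic acid or a longer alkyl chain, would move the number beyond the scatter. Also open, from the compounds shown here alone, is how a change to the phenylsulfanyl group on the neighbouring ring atom would read.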